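The source may hold more compounds than are shown below. What is called first, only, known or untested is meant among the compounds shown, and "the series" means these compounds.

Working notes on the benzyl ether series in an ADME assay on cells (Splenocyte, Mus musculus, strain BALB/c) for cytotoxicity, read by MTT assay, tested at 10 ug/mL; a lower number here means a weaker effect, a higher number a stronger effect of the compound at the concentration tested. The parent amine compound 1 `CCCCCCCCCCCCCCC(N)COCc1ccccc1` gives 12.2% in this assay. Acylation of the amine nitrogen gives compound 2 `CCCCCCCCCCCCCCC(COCc1ccccc1)NC(=O)CCCC(=O)OC`, which gives 2.5%, and the free acid compound 3 `CCCCCCCCCCCCCCC(COCc1ccccc1)NC(=O)CCCC(=O)O`, which gives 6.4%. The three numbers sit close together: a number 9.7 percentage points lower from compound 1 to compound 2 (within the scatter), a number 5.8 percentage points lower from compound 1 to compound 3 (within the scatter) and a number 3.9 percentage points higher from compound 2 to compound 3 (within the scatter). Compound 3 therefore stands within the scatter of both compound 1 and compound 2, and no ordering among the three can be read from these numbers.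

The next compound is compound 4 `CCCCCCCCCCCCCCC(CO)NC(=O)CCCC(=O)O`. It differs from compound 3 in one place: hydrogen in place of benzyl on an oxygen on a saturated carbon. Within the data shown here, none of the three measured steps touches this part of the molecule; they concern only the amine nitrogen and the oxygen of the ester, so there is no measured step that bears directly on removing the benzyl group. Among the measured compounds shown here, the only guidance is that every change made so far has stayed inside the scatter. On that basis no step beyond the scatter is expected in this assay for compound 4, and the estimated step is a number 0.4 percentage points lower from compound 3 to compound 4 (within the scatter). Compound 4 is expected to give about 6%, within a range from 0% to 16%.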

Compound 4, a percentage reported as activity, at one concentration (the size of the read-out at that concentration, not a potency): 14.5%
The estimate for compound 4 lay 8.5 percentage points below the measured number, within the range that was stated.
By their numbers in this assay, from the lowest: compounds 2, 3, 1 and 4 (each within the scatter of the next, the first and the last beyond it).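

In this assay, among these compounds, hydrogen in place of benzyl on an oxygen on a saturated carbon gives a number 8.1 percentage points higher from compound 3 to compound 4 (within the scatter), the first step at this position rather than at the amine nitrogen or the ester oxygen. The change removes 7 heavy atoms and the one six-membered aromatic ring, leaving a hydroxymethyl in place of the (benzyloxy)methyl, and even so the step stays inside the scatter, so with the acylated nitrogen and the free acid in place, the benzyl group is not shown to be needed for the read-out at this concentration. No measurement at hand bears on the reason for the size of this step.

On these data alone, whether a smaller ether such as a methyl ether, or an acetyl ester on the same oxygen, would also stay inside the scatter remains open. Also open, as far as these compounds go, is how the hydroxymethyl form reads with a free amine on the nitrogen or with a shorter chain in place of the long alkyl chain, since the present step was read only with the acylated nitrogen and free acid of compound 3.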